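The compounds below may be only part of what the source reports. "The series", "measured", "known", "first", "only" and "open" are said of these compounds alone.

Of the compounds shown here, two sharing one core have been measured in an ADME assay on L6 cells (Rattus norvegicus) for cytotoxicity, read by resazurin assay, with a stated time of 72 h; a lower number here means a stronger inhibitor, a higher number a weaker inhibitor. Compound 1 `CC(C)(C)c1ccc(C(=O)NC(=O)c2ccccc2O)cc1`, which carries tert-butyl, gives 2.3 ug/mL, and compound 2 `O=C(NC(=O)c1ccccc1O)c1ccc(F)cc1`, which carries fluoro at the same place, gives 38 ug/mL. Compound 2 therefore holds the higher of the two numbers. For the measured compounds named here, the only measured step is a 17-fold higher number from compound 1 to compound 2 (1.22 log units; beyond the scatter), a large change beyond the scatter, with fluoro in place of tert-butyl on an aromatic carbon.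

Compound 3 `O=C(NC(=O)c1ccccc1O)c1ccc(OC(F)(F)F)cc1` differs from compound 2 at that same place: trifluoromethoxy in place of fluoro on an aromatic carbon. This is trifluoromethoxy in place of fluoro on an aromatic carbon, para to a large group. Going by the values given here, no measured compound carries trifluoromethoxy, so the single measured step offers a guide to direction only, and a weak one. Moving away from fluoro here is expected to lower the number in this assay, going part of the way toward compound 1 at 2.3 ug/mL without reaching it. The expected change is a 4.8-fold lower number from compound 2 to compound 3 (0.68 log units; beyond the scatter), a moderate step. For compound 3 the estimated value is 8 ug/mL, with an expected range from 3 ug/mL to 22 ug/mL.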

Compound 3, half-maximal inhibitory concentration: 84 ug/mL
The estimate for compound 3 lay 11-fold (1.02 log units) below the measured number; the measured number lies above the stated range.
By their numbers in this assay, from the lowest: compound 1; then compound 2; then compound 3.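

In this assay, trifluoromethoxy in place of fluoro gives a 2.2-fold higher number from compound 2 to compound 3 (0.34 log units; beyond the scatter) and so moves the number further from compound 1, which shows that leaving fluoro at this place, on an aromatic carbon para to a large group, does not in itself lower the number. The two groups now stand on opposite sides of fluoro, and tert-butyl alone among the three gives a low number: the whole span across this place is a 37-fold higher number from compound 1 to compound 3 (1.56 log units; beyond the scatter) and it separates the two compounds with fluorine-bearing groups from compound 1, while trifluoromethoxy, with 5 heavy atoms against 1 for fluoro, still does not move the number toward compound 1. Nothing available on these compounds explains why the number moves in this direction.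

The three compounds do not tell whether the low number of compound 1 belongs to tert-butyl alone or would also come with a methyl group, an isopropyl group or a longer alkyl chain. They also leave open where an amine or a carboxylic acid at this place would fall relative to these three groups.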